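This account rests on a few compounds, and the source may have more. Where it says the series, first, only, none or still open, it means among the compounds named here.

Working notes on the series. In an ADME assay on microsomes from liver (Mus musculus) for metabolic stability, read by LC-MS, with a stated time of 30 min, tested at 1 uM (on this read-out lower numbers stand for a less stable compound and higher numbers for a more stable compound), compound 1 (`Cc1ccccc1S(=O)(=O)c1ccc(CNC(=O)c2cc3cnccc3[nH]2)cc1`) gives 15%. Compound 2 (`O=C(NCc1ccc(S(=O)(=O)c2ccccc2)cc1)c1nc2cnccc2[nH]1`) gives 7.3%. Going by the values given here, these two values lie within the scatter of each other, so compound 1 does not stand apart from compound 2 on the numbers so far.

The next compound is compound 3 (`O=C(NCc1ccc(S(=O)(=O)c2cccc(C(F)(F)F)c2)cc1)c1cc2cnccc2[nH]1`). Its step from compound 1 is 3-(trifluoromethyl)phenyl in place of 2-methylphenyl on a sulfonyl sulfur, which puts 3-(trifluoromethyl)phenyl in place of 2-methylphenyl on a sulfonyl sulfur, with the rest of compound 1 unchanged.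

Among the compounds with values here, no measured pair differs in one place only, so the data offer no direct guide to this change in this assay. The estimate therefore starts from compound 1 at 15% and allows a wide range. A small upward movement is expected, of a size that stays within the usual scatter. The expected change is a number 5 percentage points higher from compound 1 to compound 3 (within the scatter). For compound 3 the estimated value is 20%, with an expected range from 6% to 45%.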

Compound 3, percent of the compound remaining: 49%
Compound 3: middle estimate off by 29 percentage points, on the low side, outside the stated range (above it).
By their numbers in this assay, from the lowest: compounds 2 and 1 (each within the scatter of the next); then compound 3.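

The group on the sulfonyl sulfur proves to be a place where this assay responds strongly: 3-(trifluoromethyl)phenyl in place of 2-methylphenyl gives a number 34 percentage points higher from compound 1 to compound 3 (beyond the scatter) with the rest of compound 1 unchanged. Going by these compounds alone, this is the first change that can be read in one place, and it shows that this aryl group alone can carry a large shift in the percent of compound remaining, which the earlier pair, differing in more than one place, could not show. No measurement shown here bears on the reason for this step.

Within the data shown here, the two groups differ both in the substituent and in its printed ring position, so the single step does not tell whether the trifluoromethyl group or its location accounts for the shift, and it gives no trend across substituents. Also open, from the compounds shown here alone, is how this assay would read with a chlorine, a methoxy group or a nitrile on this phenyl ring, or with a pyridyl ring on the sulfonyl sulfur in place of the phenyl ring.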